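The source may hold more compounds than are shown below. What is called first, only, known or untested is meant among the compounds shown, and "the series" means these compounds.

Working notes on the sulfonamide series. The compounds share one core and differ only in the group on the sulfonyl sulfur. In a functional assay on CHO cells for positive allosteric modulation of muscarinic acetylcholine receptor M5 (Homo sapiens), read by calcium flux (on this read-out lower numbers stand for an effect already at smaller amounts and higher numbers for an effect only at larger amounts of compound), compound 1 `CCN(Cc1ccccc1)C(=O)C1CCN(S(=O)(=O)c2ccc(OC)cc2)CC1` gives 3310 nM; 3300 nM (2 entries), consistent across its repeated entries (the several entries of compound 1 in this assay, 3310 nM; 3300 nM (2 entries)). Compound 2 `CCN(Cc1ccccc1)C(=O)C1CCN(S(=O)(=O)c2c(C)noc2C)CC1` gives only > 10000 nM in this assay, which is a limit of the assay and not a number (the limit of > 10000 nM in this assay, at which 1 of the 2 values shown sits). On the numbers shown, compound 2 therefore stands at the weak end, beyond what compound 1 reaches.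

Compound 3 `CCN(Cc1ccccc1)C(=O)C1CCN(S(=O)(=O)c2cccnc2)CC1`, not yet measured, differs from compound 2 by pyridin-3-yl in place of 3,5-dimethyl-1,2-oxazol-4-yl on a sulfonyl sulfur. Within the data shown here, no measured step covers this pair; the values of compound 1 and compound 2 show only that the six-membered aromatic ring of compound 1 returned a number where the five-membered aromatic ring of compound 2 returned a limit. For compound 3 the expected step in this assay is an at least 2.0-fold lower number from compound 2 to compound 3 (0.30 log units; that floor lies within the scatter), a gain beyond the scatter, though modest. Compound 3 is estimated at 5000 nM, with a range from 1500 nM to 20000 nM.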

Compound 3, half-maximal effective concentration: > 10000 nM
Compound 3: no number, only a limit (the forecaster's own chance of this, stated with the estimate: 40%); middle value at least 2.0-fold (0.30 log units) away from the limit.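

Compound 2 and compound 3 each return only a limit of the assay, not a number, and no step can be read between them. Still open, on these data alone, is how far either compound lies from compound 1, and whether pyridin-3-yl or 3,5-dimethyl-1,2-oxazol-4-yl on the sulfonyl sulfur gives the lower number.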